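This account rests on a few compounds, and the source may have more. Where it says the series, first, only, none or still open, it means among the compounds named here.

Measured so far in an assay on HEK293 cells for displacement of a labelled ligand from Type-2 angiotensin II receptor (Homo sapiens), read by scintillation counting, with a stated time of 240 min; on this read-out lower numbers stand for stronger inhibition and higher numbers for weaker inhibition:
compound 1 `CC(C)Cc1cc(-c2cccc(Cn3ccnc3)c2)c(S(=O)(=O)NC(=O)OCC2CC2)s1`, 140 nM
compound 2 `CC(C)Cc1cc(-c2cccc(Cn3ccnc3)c2)c(S(=O)(=O)NC(=O)C2CC2)s1`, 340 nM

Of these two, compound 2 has the higher number, and the step of a 2.4-fold higher number from compound 1 to compound 2 (0.39 log units; beyond the scatter) is modest but beyond the scatter. Compound 3 `CCCC(=O)NS(=O)(=O)c1sc(CC(C)C)cc1-c1cccc(Cn2ccnc2)c1` has not yet been measured. It arises from compound 2 by a single change: propyl in place of cyclopropyl on a carbonyl carbon. Among the measured compounds shown here, the only step seen so far, a 2.4-fold higher number from compound 1 to compound 2 (0.39 log units; beyond the scatter), concerns a different exchange on the same carbonyl carbon, so it shows only that this part of the molecule can move the number modestly; it does not tell which way a short chain in place of a small ring will go. For the measured compounds named here, with no closer precedent, the expected step is a 1.0-fold higher number from compound 2 to compound 3 (0.01 log units; within the scatter), one that would not stand out from the scatter. Compound 3 is therefore estimated at 350 nM, with a range from 150 nM to 800 nM.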

Compound 3, inhibition constant: 300 nM
Beside the measured number, compound 3's estimate is 1.2-fold (0.07 log units) above it; the range from low to high includes it.
By their numbers in this assay, from the lowest: compound 1; then compounds 3 and 2 (each within the scatter of the next).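

In this assay the change from cyclopropyl to propyl on the carbonyl carbon gives a 1.1-fold lower number from compound 2 to compound 3 (0.05 log units; within the scatter) and so shows that, at this position, closing these carbons into a ring or leaving them as an open chain makes no difference that can be told from the scatter. The step to the open chain from the carbamate-type compound is a 2.1-fold higher number from compound 1 to compound 3 (0.33 log units; beyond the scatter) and lies beyond the scatter, so cyclopropylmethoxy now stands apart from both propyl and cyclopropyl. Nothing available here gives a reason for either result.

Still open, as far as these compounds go, is whether the oxygen of cyclopropylmethoxy or simply its greater length sets it apart, which a butoxy or a cyclopropylethyl group on the same carbonyl carbon could help separate. From the compounds shown here alone, how a longer chain such as hexyl or a branched group such as tert-butyl would fare also remains unknown.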